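Swapping Methyl for 4-Fluorophenyl on a Weak Cytotoxic Series

The compounds below may be only part of what the source reports. "The series", "measured", "known", "first", "only" and "open" are said of these compounds alone.

In a functional assay on MCF7 cells (Homo sapiens) for cytotoxicity, read by MTT assay, with a stated time of 48 h (a higher number here means a weaker inhibitor, a lower number a stronger inhibitor), compound 1 `COc1cc(COCc2cn(Cc3cc(C)cnc3Cl)nn2)cc(OC)c1OC` gives 67400 nM. That value lies within the scatter of compound 2 `COc1cc(-c2cc(COCc3cn(Cc4cc(-c5ccc(C)cc5)cnc4Cl)nn3)on2)cc(OC)c1OC` at 58400 nM, while compound 3 `COc1cc(-c2cc(COCc3cn(Cc4cc(C)cnc4Cl)nn3)on2)cc(OC)c1OC` shows a higher number, 194000 nM. Compound 4 `COc1cc(COCc2cn(Cc3cc(-c4ccc(F)cc4)cnc3Cl)nn2)cc(OC)c1OC` departs from compound 1 in one place: 4-fluorophenyl in place of methyl on an aromatic carbon. Going by the values given here, only one measured step bears on this swap: a 3.3-fold higher number from compound 2 to compound 3 (0.52 log units; beyond the scatter), with methyl in place of 4-methylphenyl on an aromatic carbon. It is a single example, on a core different from that of compound 1, and the incoming group there is not 4-fluorophenyl. Read in reverse, it points to a lower number of modest size, so this assay is expected to show a 2.5-fold lower number from compound 1 to compound 4 (0.40 log units; beyond the scatter). For compound 4 the estimate is 27000 nM, with an expected range of 10000 nM to 70000 nM.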

Compound 4, half-maximal inhibitory concentration: 96600 nM
The estimate for compound 4 lay 3.6-fold (0.55 log units) below the measured number; the whole stated range lies below it.
By their numbers in this assay, from the lowest: compounds 2, 1, 4 and 3 (each within the scatter of the next, the first and the last beyond it).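

In this assay, the swap gives a 1.4-fold higher number from compound 1 to compound 4 (0.16 log units; within the scatter), so on the core of compound 1, 4-fluorophenyl and methyl at this aromatic carbon cannot be told apart. The earlier step, a 3.3-fold higher number from compound 2 to compound 3 (0.52 log units; beyond the scatter), therefore does not carry over to this core and this incoming group. No available evidence accounts for the contrast.

The compounds shown leave open whether the contrast follows from the core or from the fluorine in place of the methyl on the phenyl ring. They also leave open whether an amine or a carboxylic acid at this carbon would shift the number.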